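The source may hold more compounds than are shown below. What is called first, only, known or untested is meant among the compounds shown, and "the series" means these compounds.

The measured compounds, with their values in an ADME assay on MT2 cells (Homo sapiens) for cytotoxicity; on this read-out lower numbers stand for higher toxicity in this test and higher numbers for lower toxicity in this test:
compound 1, `COc1nc(Nc2ccc(Cl)c(OCC=C(C)C)c2)nc(OC)n1`: 20000 nM
compound 2, `CC(C)=CCOc1cc(Nc2ncnc(N)n2)ccc1C#N`: 200 nM
compound 3, `CNc1ccnc(Nc2ccc(Cl)c(OCC=C(C)C)c2)n1`: 690 nM

Among these three numbers compound 3 stands second highest. Its nearest neighbour is compound 2, whose lower number lies beyond the scatter of this assay, so compound 2 is the more toxic of the two. Farthest away is compound 1, whose much higher number also lies beyond the scatter, so compound 1 is clearly the least toxic of the three.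

The next compound, compound 4, `CCOc1ccnc(Nc2ccc(Cl)c(OCC=C(C)C)c2)n1`, has not been measured yet. It differs from compound 3 in one place: ethoxy in place of methylamino on an aromatic carbon. The two are otherwise identical, and the change keeps the count of heavy atoms close while removing the one hydrogen-bond donor of the group.

Among the measured compounds shown here, no measured pair shows this same exchange, so no step on record guides the guess. The expectation is that the step from compound 3 to compound 4 in this assay is small, toward a higher number, and close to the edge of the scatter. Compound 4 is therefore expected to give about 1400 nM, within a range from 400 nM to 5000 nM, anchored on compound 3 because compound 3 gives 690 nM; this corresponds to an expected step of a 2.0-fold higher number from compound 3 to compound 4 (0.31 log units; beyond the scatter).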

Compound 4, half-maximal cytotoxic concentration: 19000 nM
Beside the measured number, compound 4's estimate is 14-fold (1.13 log units) below it, outside the stated range (above it).
By their numbers in this assay, from the lowest: compound 2; then compound 3; then compounds 4 and 1 (each within the scatter of the next).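

Exchanging methylamino for ethoxy on an aromatic carbon next to the ring nitrogen gives a 28-fold higher number from compound 3 to compound 4 (1.44 log units; beyond the scatter) in this assay, so a change at this single position can shift the read-out by a large margin. The earlier compounds shown here all differ in more than one place and could not isolate any one group, whereas this pair shows that the rest of the structure, held constant, does not fix the level of toxicity in this test. The exchange replaces a group that carries a hydrogen-bond donor with a slightly larger one that carries none, but nothing available explains the rise in the number.

The pair leaves open whether the shift follows the loss of the donor, the swap of nitrogen for oxygen or the longer chain, and an ethylamino or a methoxy group at this position would help to tell these apart. Among the compounds shown here, it also leaves open whether the same exchange would have a similar effect on a different core, such as the one in compound 2.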